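From nitro to amino on compound 3

This account rests on a few compounds, and the source may have more. Where it says the series, first, only, none or still open, it means among the compounds named here.

In a functional assay on MCF7 cells (Homo sapiens) for cytotoxicity, read by MTT assay, with a stated time of 96 h (on this read-out lower numbers stand for stronger inhibition and higher numbers for weaker inhibition), compound 3 `COc1cc(C(=O)c2cn(-c3ccc(C)cc3)cc2-c2cccc([N+](=O)[O-])c2)cc(OC)c1OC` gives 210 nM. This lies within the scatter of compound 2 `COc1cc(C(=O)c2cn(-c3ccc(C)cc3)cc2-c2ccccc2Cl)cc(OC)c1OC` at 180 nM. Compound 1 `COc1cc(C(=O)c2cn(-c3cccc(N)c3)cc2-c2cccc(N)c2)cc(OC)c1OC` gives 60 nM, and this lower number stands apart from that of compound 3 by more than the scatter. Compound 4 `COc1cc(C(=O)c2cn(-c3ccc(C)cc3)cc2-c2cccc(N)c2)cc(OC)c1OC` is not yet measured. It departs from compound 3 by amino in place of nitro on an aromatic carbon. Among the compounds with values here, the one measured step at this aryl group, a 1.2-fold higher number from compound 2 to compound 3 (0.07 log units; within the scatter), is small but involves no amino group. Compound 1, at 60 nM, does carry a 3-aminophenyl group, though it differs from compound 3 in more than one place. A lower number is therefore expected in this assay, with an estimated 2.6-fold lower number from compound 3 to compound 4 (0.42 log units; beyond the scatter). Compound 4 is expected at 80 nM, within an estimated range of 25 nM to 250 nM.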

Compound 4, half-maximal inhibitory concentration: 53 nM
Beside the measured number, compound 4's estimate is 1.5-fold (0.18 log units) above it; the measured number falls inside the stated range.
By their numbers in this assay, from the lowest: compounds 4 and 1 (each within the scatter of the next); then compounds 2 and 3 (each within the scatter of the next).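

In this assay, within the data shown here, amino in place of nitro gives a 4.0-fold lower number from compound 3 to compound 4 (0.60 log units; beyond the scatter) and ties a lower number to this single place on the ring, which the earlier compounds could not do. The 3-aminophenyl group in place of 2-chlorophenyl likewise gives a 3.4-fold lower number from compound 2 to compound 4 (0.53 log units; beyond the scatter) at this position. At the aromatic nitrogen, 4-methylphenyl in place of 3-aminophenyl gives a 1.1-fold lower number from compound 1 to compound 4 (0.05 log units; within the scatter) and leaves the two compounds within the scatter of each other.

Nothing shown accounts for the effect of the amino group. Going by these compounds, whether a dimethylamino or acetamido group at this place would read like amino remains open.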